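The source may report more compounds than this note shows. Statements on the series, on what has been measured and on what is new or still open speak of the compounds shown alone.

Measured so far in a functional assay on PC-3 cells (Homo sapiens), read by MTT assay, with a stated time of 48 h; on this read-out lower numbers stand for stronger inhibition and higher numbers for weaker inhibition:
- compound 1 `CCN(CC)CCNC(=O)c1ccc(C(CC)(CC)c2ccc(OCC(O)C(C)(C)C)c(C)c2)n1CC`: 220 nM
- compound 2 `CCn1c(C(=O)NCCN(C)C)ccc1C(CC)(CC)c1ccc(OCC(O)C(C)(C)C)c(C)c1`: 1630 nM
- compound 3 `CCN(CC)CCCNC(=O)c1ccc(C(CC)(CC)c2ccc(OCC(O)C(C)(C)C)c(C)c2)n1CC`: 2500 nM

Compound 3 sits at the high end of these numbers, at 2500 nM. No order can be drawn against its nearest neighbour, as a 1.5-fold higher number from compound 2 to compound 3 (0.19 log units; within the scatter) shows, while an 11-fold higher number from compound 1 to compound 3 (1.06 log units; beyond the scatter) is a large step.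

The next compound is compound 4 `C#CCNC(=O)c1ccc(C(CC)(CC)c2ccc(OCC(O)C(C)(C)C)c(C)c2)n1CC`, with the change (ethynyl in place of 2-(diethylamino)ethyl on a saturated chain carbon bound to an amide-type nitrogen). In words, ethynyl takes the place of 2-(diethylamino)ethyl on a saturated chain carbon bound to an amide-type nitrogen, so 3-(diethylamino)propyl gives way to propargyl.

Within the data shown here, three measured steps bear on this chain: a 7.4-fold higher number from compound 1 to compound 2 (0.87 log units; beyond the scatter), an 11-fold higher number from compound 1 to compound 3 (1.06 log units; beyond the scatter) and a 1.5-fold higher number from compound 2 to compound 3 (0.19 log units; within the scatter). The first two are sizeable, and both start from compound 1 at 220 nM. The third, between the two higher values, stays within the scatter. Every measured compound keeps a terminal amino group, so none of these steps matches the change directly, and they serve only as a rough guide to size.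

The expected step is a 1.4-fold higher number from compound 3 to compound 4 (0.15 log units; within the scatter), which means no shift beyond the scatter is anticipated in this assay, with a slight lean towards a higher number. The estimate for compound 4 is 3500 nM, with an expected range from 700 nM to 15000 nM.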

Compound 4, half-maximal inhibitory concentration: 16200 nM
For compound 4 the middle estimate is 4.6-fold (0.67 log units) below the measured one, outside the stated range (above it).
By their numbers in this assay, from the lowest: compound 1; then compounds 2 and 3 (each within the scatter of the next); then compound 4.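

In this assay, propargyl on the amide nitrogen gives a higher number than each of the amine-bearing chains, with a 6.5-fold higher number from compound 3 to compound 4 (0.81 log units; beyond the scatter) and a 9.9-fold higher number from compound 2 to compound 4 (1.00 log units; beyond the scatter) and a 74-fold higher number from compound 1 to compound 4 (1.87 log units; beyond the scatter) all beyond the scatter. The earlier steps only compared chains that keep a terminal amino group, whereas compound 4 has none, and among these four compounds the three with a terminal amino group all give lower numbers than the one without, with no compound going against that order. The compounds shown carry no evidence on what lies behind this step.

The change removes the diethylamino group and shortens the chain, and it also brings in a triple bond, so these contributions cannot be told apart from this series alone. A plain propyl group on the amide nitrogen would separate the triple bond from the loss of the amine, while a 2-(morpholin-4-yl)ethyl or 2-aminoethyl chain would test how far the nature of the terminal amine matters.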